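Exchanging the carbamoyl-bearing ring on the shared core

This account rests on a few compounds, and the source may have more. Where it says the series, first, only, none or still open, it means among the compounds named here.

Compound 2 `COc1ccc(-c2cncc(C(=O)N(C)C)c2)cc1S(=O)(=O)Nc1cccc(NCCNC(=O)c2cccc(C)c2)c1` stands highest of the three measured compounds in a functional assay on CHO-RD-HGA16 cells for agonist activity at Orexin/Hypocretin receptor type 1 (Homo sapiens), read by fluorescence and calcium flux, with a stated time of 30 min (on this read-out lower numbers stand for smaller maximal responses and higher numbers for larger maximal responses), where compound 2 gives 105%. Compound 3 `COc1ccc(-c2ccnc(C(=O)N(C)C)c2)cc1S(=O)(=O)Nc1cccc(NCCNC(=O)c2cccc(C)c2)c1` gives 101%, and compound 1 `COc1ccc(-c2cc(C(=O)N(C)C)ccn2)cc1S(=O)(=O)Nc1cccc(NCCNC(=O)c2cccc(C)c2)c1` gives 93%. Compound 4 `COc1ccc(-c2csc(C(=O)N(C)C)n2)cc1S(=O)(=O)Nc1cccc(NCCNC(=O)c2cccc(C)c2)c1` differs from compound 2 in one place: 2-(dimethylcarbamoyl)-1,3-thiazol-4-yl in place of 5-(dimethylcarbamoyl)pyridin-3-yl on an aromatic carbon. The measured steps all exchange one ring carrying the dimethylcarbamoyl group for another such ring, and they were small: a number 12 percentage points higher from compound 1 to compound 2 (beyond the scatter), a number 8 percentage points higher from compound 1 to compound 3 (within the scatter), and a number 4 percentage points lower from compound 2 to compound 3 (within the scatter). Every measured compound reaches roughly a full response, so this further ring exchange is expected to leave the maximal response much where it is; the expected step is a number 5 percentage points lower from compound 2 to compound 4 (within the scatter). For compound 4 the estimate is 100%, with a range from 85% to 115%.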

Compound 4, largest response reached (Emax), in percent of the reference or control that the assay uses: 51%
The estimate for compound 4 lay 49 percentage points above the measured number, outside the stated range (below it).
By their numbers in this assay, from the lowest: compound 4; then compounds 1, 3 and 2 (each within the scatter of the next, the first and the last beyond it).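

Placing 2-(dimethylcarbamoyl)-1,3-thiazol-4-yl on this aromatic carbon, para to a methoxy group, sharply reduces the maximal response in this assay: a number 54 percentage points lower from compound 2 to compound 4 (beyond the scatter), a number 50 percentage points lower from compound 3 to compound 4 (beyond the scatter) and a number 42 percentage points lower from compound 1 to compound 4 (beyond the scatter). This position therefore does not accept every ring carrying the dimethylcarbamoyl group, although the three pyridinyl versions all gave close to a full response. Nothing available here explains the drop.

The compounds shown leave open whether ring size or the sulfur matters, as both change together in this step. A thiophene or 1,3-oxazole ring carrying the same dimethylcarbamoyl group would bear on that question.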